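Returning an Aromatic Ring to the Carbonyl Carbon

The compounds below may be only part of what the source reports. "The series", "measured", "known", "first", "only" and "open" are said of these compounds alone.

Compound 3 `O=C(/C(=C\c1ccc(O)c([N+](=O)[O-])c1)SCc1ccc(Br)cc1)C1CCNC1` was tested in a functional assay on DU-145 cells (Homo sapiens) for inhibition, read by trypan blue exclusion, with a stated time of 96 h (on this read-out lower numbers stand for stronger inhibition of growth and higher numbers for weaker inhibition of growth), where it reaches > 100000 nM, a limit of the assay rather than a number. Compound 1 `CN(C)c1ccc(/C=C(/Sc2ccc(Br)cc2)C(=O)c2ccc(Cl)cc2)cc1` likewise reaches > 100000 nM, again a limit. Compound 2 `COc1ccc(C(=O)/C(=C\c2ccc(O)c([N+](=O)[O-])c2)SCc2ccc(Br)cc2)cc1` gives 10000 nM. Compound 3 thus sits at the level described by the limit of > 100000 nM in this assay, at which 2 of the 3 values shown sit, with no number of its own to compare.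

The change from compound 3 to compound 4 `O=C(/C(=C\c1ccc(O)c([N+](=O)[O-])c1)SCc1ccc(Br)cc1)c1ccc(C(F)(F)F)cc1` is 4-(trifluoromethyl)phenyl in place of pyrrolidin-3-yl on a carbonyl carbon. Among the compounds with values here, one measured step bears on it: an at least 10-fold higher number from compound 2 to compound 3 (1.00 log units; beyond the scatter), which runs the opposite way, from an aromatic ring on the carbonyl carbon to pyrrolidin-3-yl. Reversing that exchange, though with 4-(trifluoromethyl)phenyl rather than 4-methoxyphenyl, suggests that a sizeable fall in the number, back toward the region of compound 2, is to be expected. The expected step is an at least 5.0-fold lower number from compound 3 to compound 4 (0.69 log units; beyond the scatter). Compound 4 is accordingly estimated at 20000 nM, with a likely range from 5000 nM to 100000 nM.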

Compound 4, concentration for 50% growth inhibition: 10000 nM
For compound 4 the middle estimate is 2.0-fold (0.30 log units) above the measured one; the range from low to high includes it.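

With an aromatic ring back on the carbonyl carbon, this assay shows an at least 10-fold lower number from compound 3 to compound 4 (1.00 log units; beyond the scatter), so the loss seen with pyrrolidin-3-yl is now matched by a recovery with a second, different ring. The group carried on that ring makes little difference between these two examples, since trifluoromethyl in place of methoxy gives no change at the digits printed from compound 2 to compound 4 (within the scatter). Compound 3 has only a limit and not a number, so the full size of its step remains unknown, and it is not alone in this: the limit of > 100000 nM in this assay, at which 2 of the 4 values shown sit.

From the compounds shown here alone, whether an unsubstituted phenyl ring or an open-chain amine on the carbonyl carbon would read like compound 4 or like compound 3 remains open. Also unknown is whether a carboxylic acid or a nitrile on the aromatic ring would shift the number at all.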